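A few compounds are considered here, and "the series" means these few. Any claim that something is new, unique, unknown or untested is made for them only; others in the source may bear on it.

Measured so far in a functional assay on MCF cells (Homo sapiens) for antiproliferative activity, with a stated time of 72 h; a higher number here means a weaker inhibitor, a lower number a stronger inhibitor:
compound 1, `OC[C@H]1O[C@@H](n2cnc3c(NCc4cccc(F)c4)ncnc32)[C@H](O)[C@@H]1O`, 15300 nM
compound 2, `OC[C@H]1O[C@@H](n2cnc3c(NCc4ccc(F)cc4)ncnc32)[C@H](O)[C@@H]1O`, 21000 nM
compound 3, `OC[C@H]1O[C@@H](n2cnc3c(NCc4cccc(Br)c4)ncnc32)[C@H](O)[C@@H]1O`, a limit only

Compound 3 gives > 166000 nM, which is a limit of the assay and not a number. Of the two numbers, compound 2 holds the higher, yet a 1.4-fold higher number from compound 1 to compound 2 (0.14 log units; within the scatter), so compound 1 and compound 2 cannot be told apart. Compound 4, `OC[C@H]1O[C@@H](n2cnc3c(NCc4ccc(F)c(F)c4F)ncnc32)[C@H](O)[C@@H]1O`, is not yet measured; it differs from compound 2 by 2,3,4-trifluorophenyl in place of 4-fluorophenyl on a saturated chain carbon bound to a nitrogen on an aromatic ring. The measured steps give little guidance: a 1.4-fold higher number from compound 1 to compound 2 (0.14 log units; within the scatter) shows that shifting one fluorine matters little, while an at least 10-fold higher number from compound 1 to compound 3 (1.03 log units; beyond the scatter) and an at least 7.9-fold higher number from compound 2 to compound 3 (0.89 log units; beyond the scatter) concern bromine, not added fluorine. Going by the values given here, no step shows what extra fluorines do, so no change beyond the scatter is expected. Compound 4 is therefore estimated at 25000 nM, from 8000 nM to 80000 nM, an expected step of a 1.2-fold higher number from compound 2 to compound 4 (0.08 log units; within the scatter).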

Compound 4, half-maximal inhibitory concentration: > 166000 nM
Compound 4 gave a limit, no number; the forecaster's own chance of this, stated with the estimate: 10%; middle value at least 6.6-fold (0.82 log units) from the limit.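

The 2,3,4-trifluorophenyl group weakens the compound clearly: it gives an at least 7.9-fold higher number from compound 2 to compound 4 (0.89 log units; beyond the scatter), and against the 3-fluorophenyl group it gives an at least 10-fold higher number from compound 1 to compound 4 (1.03 log units; beyond the scatter). At this position added fluorine, and not only bromine, can therefore carry a compound out of the measurable range, while the step between compound 3 and compound 4 cannot be read. Compound 4 stands at a limit and not at a number: the limit of > 166000 nM in this assay, at which 2 of the 4 values shown sit.

Still open, as far as these compounds go, is whether a difluorophenyl group already brings this loss. Also open, from the compounds shown here alone, is whether a chloro or methoxy group on the phenyl ring would retain measurable activity.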